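The source may report more compounds than this note shows. Statements on the series, on what has been measured and on what is new or still open speak of the compounds shown alone.

Measured so far:
- compound 1, `Cc1c(OCCCCOc2ccc(F)c(C(N)=O)c2)ccc(C(=O)CC(C)(C)C)c1O`: "not active" (no number reported) in an assay for positive allosteric modulation of metabotropic glutamate receptor 3 (Rattus norvegicus) (on this read-out higher numbers stand for an effect only at larger amounts of compound and lower numbers for an effect already at smaller amounts), with no number given
- compound 2, `Cc1c(OC[C@@H](C)COc2ccc(Cl)c(C(=O)O)c2)ccc(C(=O)CC(C)(C)C)c1O`: 2200 nM

In this assay, for the measured compounds named here, compound 2 is the only compound with a number; compound 1 stands beside it without one. Compound 3, `Cc1c(OC[C@@H](C)COc2ccc3c(c2)C(=O)NC3)ccc(C(=O)CC(C)(C)C)c1O`, has not yet been tested. It differs from compound 2 in one place: a group of 10 heavy atoms (8 carbon, 1 nitrogen, 1 oxygen; one five-membered non-aromatic ring with 1 hetero atom, one six-membered aromatic ring of carbon only) in place of a group of 10 heavy atoms (7 carbon, 2 oxygen, 1 chlorine; one six-membered aromatic ring of carbon only), on an oxygen on a saturated carbon. The 3-carboxy-4-chlorophenyl group leaves and a group of 10 heavy atoms carrying a five-membered non-aromatic ring with one hetero atom fused to a six-membered aromatic ring of carbon only enters, on the oxygen on a saturated carbon.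

Going by the values given here, no measured pair shows the effect of such an exchange, so no step size is known. The expected step from compound 2 to compound 3 is a 1.2-fold lower number from compound 2 to compound 3 (0.09 log units; within the scatter), judged as small and possibly within the usual scatter, in either direction. Compound 3 is therefore estimated at 1800 nM, with a range from 350 nM to 9000 nM.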

Compound 3, half-maximal effective concentration: "not active" (no number reported)
No number was reported for compound 3, so the estimate cannot be set against anything.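

In this assay, for the compounds shown here, compound 3 has no reported number, so no step from compound 2 to compound 3 can be read. The compounds shown leave open which groups in place of the 3-carboxy-4-chlorophenyl group give a measurable effect. Nothing here bears on why compound 3 gave no number.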